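Piperidine nitrogen substituents in a sulfonamide series

The source may report more compounds than this note shows. Statements on the series, on what has been measured and on what is new or still open speak of the compounds shown alone.

Measured so far:
compound 1 `O=C(c1ccc(C(F)(F)F)cc1)N1CCC(NS(=O)(=O)c2cc(S(=O)(=O)c3ccccc3)ccc2C(F)(F)F)CC1` 400 nM
compound 2 `O=C(O)c1cccc(S(=O)(=O)N2CCC(NS(=O)(=O)c3cc(S(=O)(=O)c4ccccc4)ccc3C(F)(F)F)CC2)c1` 20 nM

Compound 2 holds the lowest of the two numbers in an assay on isolated protein for displacement of a labelled ligand from secreted frizzled-related protein 1 (Homo sapiens), read by fluorescence polarization, with a stated time of 30 min; a lower number here means a stronger inhibitor, a higher number a weaker inhibitor; its nearest neighbour is compound 1, and the step of a 20-fold lower number from compound 1 to compound 2 (1.30 log units; beyond the scatter) is large. Compound 3 `CC(C)(O)CCN1CCC(NS(=O)(=O)c2cc(S(=O)(=O)c3ccccc3)ccc2C(F)(F)F)CC1` carries 3-hydroxy-3-methylbutyl in place of (3-carboxyphenyl)sulfonyl on an amine nitrogen in a ring. Among the measured compounds shown here, no measured step covers an alkyl group at this position; the one step available shows only that the group on the ring nitrogen matters strongly. A weaker number than compound 2 is therefore expected, of uncertain size. Compound 3 is estimated at 300 nM, range 60 nM to 1500 nM, an expected step of a 15-fold higher number from compound 2 to compound 3 (1.18 log units; beyond the scatter).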

Compound 3, half-maximal inhibitory concentration: 200 nM
Beside the measured number, compound 3's estimate is 1.5-fold (0.18 log units) above it; the range from low to high includes it.
By their numbers in this assay, from the lowest: compound 2; then compounds 3 and 1 (each within the scatter of the next).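

In this assay, a group with no ring on the amine nitrogen in a ring gives up much of what (3-carboxyphenyl)sulfonyl holds, with a 10-fold higher number from compound 2 to compound 3 (1.00 log units; beyond the scatter). Set against (4-(trifluoromethyl)phenyl)carbonyl, the same 3-hydroxy-3-methylbutyl chain gives a 2.0-fold lower number from compound 1 to compound 3 (0.30 log units; within the scatter), so an aromatic ring at this position is not required to reach that level. Nothing available accounts for either step.

Open, as far as these compounds go, is whether the carboxylic acid or the sulfonyl link in compound 2 carries its number. An alkyl chain ending in a carboxylic acid, or a benzoyl group bearing one, would separate the two.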